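Varying the group on the ring nitrogen: compound 4

The source may report more compounds than this note shows. Statements on the series, on what has been measured and on what is new or still open speak of the compounds shown alone.

Compound 1 `Nc1ccccc1NC(=O)c1ccc(CSC(=S)N2CCN(c3ccc(Cl)cc3)CC2)cc1`, compound 2 `Nc1ccccc1NC(=O)c1ccc(CSC(=S)N2CCN(C3CCCCC3)CC2)cc1` and compound 3 `Nc1ccccc1NC(=O)c1ccc(CSC(=S)N2CCN(c3ccc(F)cc3)CC2)cc1` share one core and differ only in the group on an amine nitrogen in a ring. In a functional assay on MGC-803 cells (Homo sapiens) for antiproliferative activity, read by CCK-8 assay, with a stated time of 72 h, tested at 2 uM (on this read-out lower numbers stand for a weaker effect and higher numbers for a stronger effect at the one concentration tested), compound 1 gives 15%, compound 2 gives 16.9% and compound 3 gives 18.8%. Compound 3 holds the highest of the three numbers shown, yet a number 3.8 percentage points higher from compound 1 to compound 3 (within the scatter) and a number 1.9 percentage points higher from compound 2 to compound 3 (within the scatter) both lie within the scatter, as does a number 1.9 percentage points higher from compound 1 to compound 2 (within the scatter); the three sit on one level. Compound 4 `Nc1ccccc1NC(=O)c1ccc(CSC(=S)N2CCN(Cc3cccnc3)CC2)cc1` carries (pyridin-3-yl)methyl in place of 4-fluorophenyl on an amine nitrogen in a ring. The steps bearing on this are the two earlier changes at the same nitrogen, a number 1.9 percentage points higher from compound 1 to compound 2 (within the scatter) and a number 1.9 percentage points higher from compound 2 to compound 3 (within the scatter), neither beyond the scatter, so no step beyond the scatter is expected in this assay. Compound 4 is estimated at 17%, range 6% to 30%. The expected step is a number 1.8 percentage points lower from compound 3 to compound 4 (within the scatter).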

Compound 4, a percentage reported as inhibition, at one concentration (the size of the read-out at that concentration, not a potency): 37.7%
Estimate against measurement, compound 4: 20.7 percentage points below; the measured number lies above the stated range.
By their numbers in this assay, from the lowest: compounds 1, 2 and 3 (each within the scatter of the next); then compound 4.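

In this assay the group on the amine nitrogen in a ring now moves the number, with a number 18.9 percentage points higher from compound 3 to compound 4 (beyond the scatter) and a number 20.8 percentage points higher from compound 2 to compound 4 (beyond the scatter) and a number 22.7 percentage points higher from compound 1 to compound 4 (beyond the scatter) while the three earlier groups stay on one level. (Pyridin-3-yl)methyl differs from 4-fluorophenyl both in its ring hetero atom and in its methyl link, and this one change cannot separate the two. Nothing measured on hand accounts for the rise.

Open, going by these compounds, is whether benzyl or pyridin-3-yl alone keeps this gain. Also open, on these data alone, is whether (pyridin-2-yl)methyl or (pyridin-4-yl)methyl matches it.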